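Swapping 2-methylphenyl for 3-methoxyphenyl: an expected small step

The compounds below may be only part of what the source reports. "The series", "measured", "known", "first", "only" and "open" are said of these compounds alone.

In an ADME assay on MT4 cells (Homo sapiens) for cytotoxicity, read by MTT assay, with a stated time of 5 days (a lower number here means that less compound is tolerated, a higher number that more compound is tolerated), compound 3 (`Cc1ccccc1COc1ccnc(Nc2ccc(C#N)cc2)n1`) gives 12000 nM. Compound 1 (`N#Cc1ccc(Nc2nccc(OCc3ccc(Br)cc3)n2)cc1`) gives 16000 nM, so these two sit together, with a 1.3-fold lower number from compound 1 to compound 3 (0.12 log units; within the scatter). Compound 2 (`N#Cc1ccc(Nc2nccc(OCc3ccccc3F)n2)cc1`) stands well apart at 151000 nM, and the change to compound 3 is a 13-fold lower number from compound 2 to compound 3 (1.10 log units; beyond the scatter).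

Compound 4 (`COc1cccc(COc2ccnc(Nc3ccc(C#N)cc3)n2)c1`) has 3-methoxyphenyl in place of 2-methylphenyl on a saturated chain carbon bound to an oxygen on an aromatic ring. Among the compounds with values here, no measured compound carries this group, so the evidence is indirect. Replacing the group at this place left the number unmoved in one case, a 1.3-fold lower number from compound 1 to compound 3 (0.12 log units; within the scatter), but not in another, a 9.4-fold higher number from compound 1 to compound 2 (0.97 log units; beyond the scatter). Compound 2 therefore goes against any rule that this group hardly matters, and it leaves the upper side more open than the lower.

A step within the scatter is the likeliest outcome, tilted slightly upward. The expected step is a 1.5-fold higher number from compound 3 to compound 4 (0.18 log units; within the scatter). For compound 4 the estimated value is 18000 nM, with an expected range of 7000 nM to 60000 nM.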

Compound 4, half-maximal cytotoxic concentration: 118000 nM
Beside the measured number, compound 4's estimate is 6.6-fold (0.82 log units) below it, outside the stated range (above it).
By their numbers in this assay, from the lowest: compounds 3 and 1 (each within the scatter of the next); then compounds 4 and 2 (each within the scatter of the next).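

In this assay, within the data shown here, 3-methoxyphenyl in place of 2-methylphenyl gives a 9.8-fold higher number from compound 3 to compound 4 (0.99 log units; beyond the scatter), so compound 2 is no longer the only compound far from compound 3 and a second group at this place reaches the same upper level. That level is shared, with a 1.3-fold lower number from compound 2 to compound 4 (0.11 log units; within the scatter), while a 7.4-fold higher number from compound 1 to compound 4 (0.87 log units; beyond the scatter) places compound 4 clear of the 4-bromophenyl compound as well, so the four compounds now form two sets, compounds 1 and 3 in one and compounds 2 and 4 in the other. No measurement at hand accounts for this division.

The compounds shown leave open which set 2-methoxyphenyl or 3-methylphenyl would join, so the effect of the group itself cannot yet be separated from that of its location on the phenyl ring. They also leave open how a group carrying an amine or a carboxylic acid would stand at this place.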